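Nitrobenzene sulfone amides: indoline replaces piperidine

This account rests on a few compounds, and the source may have more. Where it says the series, first, only, none or still open, it means among the compounds named here.

Measured compounds:
compound 1 `CS(=O)(=O)c1ccc(C(=O)N2CCC(C(=O)N(Cc3ccccc3)c3ccccc3)CC2)cc1[N+](=O)[O-]`: > 60000 nM
compound 2 `CN(Cc1cccc(F)c1)C(=O)CCCNC(=O)c1ccc(S(C)(=O)=O)c([N+](=O)[O-])c1`: > 60000 nM
compound 3 `CS(=O)(=O)c1ccc(C(=O)NCCC(=O)N2CCCCC2)cc1[N+](=O)[O-]`: > 60000 nM

In an assay on isolated protein for inhibition of thyroid hormone receptor alpha (Homo sapiens), read by fluorescence polarization (on this read-out lower numbers stand for stronger inhibition and higher numbers for weaker inhibition), compound 1 gives only a limit, > 60000 nM. Compound 2 likewise gives only a limit, > 60000 nM. Compound 3 also gives only a limit, > 60000 nM. All three values therefore sit at the limit of > 60000 nM in this assay, at which 3 of the 3 values shown sit, and no ordering among them can be read from the numbers. Compound 4 `CS(=O)(=O)c1ccc(C(=O)NCCC(=O)N2CCc3ccccc32)cc1[N+](=O)[O-]` is next, differing from compound 3 by 2,3-dihydro-1H-indol-1-yl in place of piperidin-1-yl on a carbonyl carbon. For the measured compounds named here, with every measured value at the limit, no step between measured compounds exists to calibrate this change, so no shift beyond the scatter is expected. The step from compound 3 to compound 4 is thus estimated as a step that the limit leaves unreadable from compound 3 to compound 4, and compound 4 is expected to show 80000 nM, somewhere from 20000 nM to 300000 nM in this assay.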

Compound 4, half-maximal inhibitory concentration: > 60000 nM
Compound 4: a limit, no number (the forecaster's own chance of this, stated with the estimate: 85%); the middle value does not contradict the limit.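

Compound 3 and compound 4 each give only a limit in this assay, so no step can be read between them: the limit of > 60000 nM in this assay, at which 4 of the 4 values shown sit.

The compounds shown leave open whether 2,3-dihydro-1H-indol-1-yl and piperidin-1-yl differ at all in this assay, and what on this series would give a measurable value.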